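Swapping a Substituted Pyrazole for an Indole: Expected Clearance

This account rests on a few compounds, and the source may have more. Where it says the series, first, only, none or still open, it means among the compounds named here.

Measured so far:
- compound 1 `CC(C)n1cc(-c2cc(C(O)(C(F)(F)F)C(F)(F)F)cnc2N2CCN(S(=O)(=O)c3ccc(N)nc3)CC2)cn1`: 198 mL.min-1.g-1
- compound 2 `CC(C)(C)n1cc(-c2cc(C(O)(C(F)(F)F)C(F)(F)F)cnc2N2CCN(S(=O)(=O)c3ccc(N)nc3)CC2)cn1`: 459 mL.min-1.g-1
- compound 3 `Nc1ccc(S(=O)(=O)N2CCN(c3ncc(C(O)(C(F)(F)F)C(F)(F)F)cc3-c3cncc(F)c3)CC2)cn1`: 19 mL.min-1.g-1

These three share one core and differ only in the aromatic group attached to it. In an ADME assay (liver) for metabolic stability, with Liver microsome (Rattus norvegicus) as the target, using microsomes and NADPH, with a stated time of 30 min, tested at 1 uM (a higher number here means faster removal of the compound, a lower number slower removal), compound 2 has the highest number of the three: compound 1 sits nearest, with a 2.3-fold higher number from compound 1 to compound 2 (0.37 log units; beyond the scatter) between them, and compound 3 sits furthest, with a 24-fold lower number from compound 2 to compound 3 (1.38 log units; beyond the scatter).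

The new compound 4 `Nc1ccc(S(=O)(=O)N2CCN(c3ncc(C(O)(C(F)(F)F)C(F)(F)F)cc3-c3cc4ccccc4[nH]3)CC2)cn1` changes compound 2 in one place: 1H-indol-2-yl in place of 1-(tert-butyl)-1H-pyrazol-4-yl on an aromatic carbon.

Going by the values given here, two measured steps bear on this. The step of a 2.3-fold higher number from compound 1 to compound 2 (0.37 log units; beyond the scatter) shows that the group on the pyrazole nitrogen shifts the number modestly. The step of a 24-fold lower number from compound 2 to compound 3 (1.38 log units; beyond the scatter) shows that replacing the whole 1-(tert-butyl)-1H-pyrazol-4-yl with a different aromatic group can lower the number by a large amount. Compound 4 also loses that group, but gains a two-ring aromatic group with a hydrogen-bond donor rather than a small fluorinated pyridine, so a lower number than compound 2 is expected, though not as low as compound 3.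

Compound 4 is therefore expected to show a 5.7-fold lower number from compound 2 to compound 4 (0.76 log units; beyond the scatter) in this assay, with an estimate of 80 mL.min-1.g-1 and a likely range from 25 mL.min-1.g-1 to 250 mL.min-1.g-1.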

Compound 4, intrinsic clearance in microsomes: 146 mL.min-1.g-1
The estimate for compound 4 lay 1.8-fold (0.26 log units) below the measured number; low and high end bracket the measured number.
By their numbers in this assay, from the lowest: compound 3; then compounds 4 and 1 (each within the scatter of the next); then compound 2.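

In this assay, the change gives a 3.1-fold lower number from compound 2 to compound 4 (0.50 log units; beyond the scatter), although the leaving and entering groups both have 9 heavy atoms, so between these two compounds the heavy-atom count of the group on this aromatic carbon does not settle the number. The 1H-indol-2-yl group also stands well apart from the 5-fluoropyridin-3-yl group, with a 7.7-fold higher number from compound 3 to compound 4 (0.89 log units; beyond the scatter), while the result a 1.4-fold lower number from compound 1 to compound 4 (0.13 log units; within the scatter) means that 1H-indol-2-yl and 1-isopropyl-1H-pyrazol-4-yl cannot be told apart in this measurement. The data shown offer no independent measurement that would explain any of these differences.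

The compounds shown leave open whether the hydrogen on the indole nitrogen matters, which a 1-methyl-1H-indol-2-yl group in the same place could test. Going by these compounds alone, they also leave open whether a fluorine or a nitrile on the six-membered ring of the indole would bring the number closer to that of compound 3, which carries the only fluorinated aromatic group among the four.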